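Ester-to-amide change at the acrylate terminus

A few compounds are considered here, and "the series" means these few. Any claim that something is new, unique, unknown or untested is made for them only; others in the source may bear on it.

In an ADME assay (liver) for pharmacokinetics, with Liver microsome (Homo sapiens) as the target, using microsomes (on this read-out higher numbers stand for a longer-lived compound and lower numbers for a shorter-lived compound), compound 1 `CCOc1cc(NC(=O)C2(NC(=O)c3ccc4c(C5CCCC5)c(-c5ncc(Cl)cn5)n(C)c4c3)CCC2)ccc1/C=C/C(=O)OCC(Cl)(Cl)Cl` gives > 5 h, a limit of the assay rather than a number.
In this assay compound 2 `CCOc1cc(NC(=O)C2(NC(=O)c3ccc4c(C5CCCC5)c(-c5ncc(Cl)cn5)n(C)c4c3)CCC2)ccc1/C=C/C(=O)OCC(=O)OCc1ccc(Cl)cc1` gives 5.62 h.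

Among the measured compounds shown here, compound 2 holds the only plain number in this assay; the other value is a limit, as in the limit of > 5 h in this assay, at which 1 of the 2 values shown sits. The step that the limit leaves unreadable from compound 1 to compound 2 therefore cannot be read in size. Compound 3 `CCOc1cc(NC(=O)C2(NC(=O)c3ccc4c(C5CCCC5)c(-c5ncc(Cl)cn5)n(C)c4c3)CCC2)ccc1/C=C/C(=O)OCC(=O)N1CCCC1` differs from compound 2 by pyrrolidin-1-yl in place of (4-chlorobenzyl)oxy on a carbonyl carbon. For the measured compounds named here, no measured step touches this position or this kind of change, so the only anchor is the value of compound 2, and both measured compounds sit in the long-lived region. The expectation is that the change brings no step beyond the scatter, so that a 1.1-fold higher number from compound 2 to compound 3 (0.03 log units; within the scatter) is expected. For compound 3 the estimated half-life is 6 h, with a range from 3 h to 12 h, and a fair chance that only a limit is reported.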

Compound 3, half-life: 1.65 h
Compound 3: middle estimate off by 3.6-fold (0.56 log units), on the high side; measured number below the stated range.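

In this assay this position responds to the group on the carbonyl carbon: pyrrolidin-1-yl in place of (4-chlorobenzyl)oxy brings a 3.4-fold lower number from compound 2 to compound 3 (0.53 log units; beyond the scatter), the first step in the series with a readable size. (Pyrrolidin-1-yl)carbonyl in place of trichloromethyl brings an at least 3.0-fold lower number from compound 1 to compound 3 (0.48 log units; beyond the scatter), which makes compound 3 the shortest-lived of the compounds shown. The step from compound 1 to compound 2 cannot be read, so the two ester compounds cannot be ordered against each other: the limit of > 5 h in this assay, at which 1 of the 3 values shown sits.

The change swaps the linking atom and the size of the group together, so the compounds shown do not tell which of the two goes with the shorter half-life. A 4-chlorobenzylamino group on the same carbonyl carbon would separate the two, while a carboxylic acid at this place remains an open case.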